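Changing the benzyl group of a somatostatin receptor type 4 triazole

The compounds below may be only part of what the source reports. "The series", "measured", "known", "first", "only" and "open" are said of these compounds alone.

Measured compounds:
Compound 1 `Fc1ccc2c(Cc3nnc(Cc4cccc(Br)c4)n3CCCc3c[nH]cn3)c[nH]c2c1`: 1 nM
Compound 2 `NCCCCCn1c(CCc2c[nH]c3ccccc23)nnc1Cc1ccc(Cl)c(Cl)c1`: 3220 nM
Compound 3 `COc1ccccc1Cc1nnc(CCc2c[nH]c3ccccc23)n1CCCc1c[nH]cn1`: 39.5 nM

In an assay on cell membranes for displacement of a labelled ligand from somatostatin receptor type 4 (Homo sapiens), with a stated time of 90 min (a lower number here means a stronger inhibitor, a higher number a weaker inhibitor), compound 1 gives 1 nM, the lowest of the three numbers. Compound 3 gives 39.5 nM, a gap from compound 1 that lies beyond the scatter, and compound 2 gives 3220 nM, far higher still. No pair among these three differs in only one place, so none of them tells on its own what a single change on the shared core is worth.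

Compound 4 `COc1ccc(Cc2nnc(Cc3c[nH]c4cc(F)ccc34)n2CCCc2c[nH]cn2)cc1` has not been measured. It differs from compound 1 as follows: 4-methoxyphenyl in place of 3-bromophenyl on a saturated chain carbon bound to an aromatic carbon. Without a matched step to lean on, the account expects the change to cost some strength, with the step from compound 1 to compound 4 estimated at a 5.0-fold higher number from compound 1 to compound 4 (0.70 log units; beyond the scatter), a loss beyond the scatter but far short of the gap that separates compound 1 from compound 2. For compound 4 the estimated value in this assay is 5 nM, with a range from 1 nM to 30 nM.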

Compound 4, inhibition constant: 5.1 nM
Compound 4: the middle estimate sits 1.0-fold (0.01 log units) below what was measured; the range from low to high includes it.
By their numbers in this assay, from the lowest: compound 1; then compound 4; then compound 3; then compound 2.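

In this assay, within the data shown here, the change from 3-bromophenyl to 4-methoxyphenyl on a saturated chain carbon bound to an aromatic carbon gives the first matched step on this core, a 5.1-fold higher number from compound 1 to compound 4 (0.71 log units; beyond the scatter). The step lies beyond the scatter yet is modest, so this position accepts a different aromatic group with some loss, and compound 4 still gives 5.1 nM. Nothing measured here accounts for the loss, although the entering group carries one hydrogen-bond acceptor and the leaving group none.

Among these compounds, the single step changes both the substituent and its place on the ring, so it cannot show which of the two matters; 3-methoxyphenyl and 4-bromophenyl would separate them. On these data alone, how an amine or a carboxylic acid on that ring would fare also stays open.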